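Positional swap of a chlorophenyl on the acylthiosemicarbazide

This account rests on a few compounds, and the source may have more. Where it says the series, first, only, none or still open, it means among the compounds named here.

Compound 1 `COc1ccccc1C(=O)NC(=S)NNc1ncnc2ccccc12`: 8700 nM
Compound 2 `O=C(NC(=S)NNc1ncnc2ccccc12)c1ccc(F)cc1`: 4590 nM
Compound 3 `O=C(NC(=S)NNc1ncnc2ccccc12)c1cccc(Cl)c1`: 3540 nM

Of the compounds shown here, three sharing one core have been measured in a functional assay on MCF7 cells (Homo sapiens) for cytotoxicity, read by MTT assay, with a stated time of 72 h; on this read-out higher numbers stand for weaker inhibition and lower numbers for stronger inhibition. Compound 3 gives the lowest number of the three: the step of a 2.5-fold lower number from compound 1 to compound 3 (0.39 log units; beyond the scatter) lies beyond the scatter, while the step of a 1.3-fold lower number from compound 2 to compound 3 (0.11 log units; within the scatter) does not, so compound 3 and compound 2 cannot be ranked against each other. The step of a 1.9-fold lower number from compound 1 to compound 2 (0.28 log units; within the scatter) is likewise within the scatter.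

Compound 4 `O=C(NC(=S)NNc1ncnc2ccccc12)c1ccccc1Cl` differs from compound 3 by 2-chlorophenyl in place of 3-chlorophenyl on a carbonyl carbon. All three measured steps are exchanges of the aryl group on the same carbonyl carbon, and each was small, the largest being a 2.5-fold lower number from compound 1 to compound 3 (0.39 log units; beyond the scatter). The move of the chlorine around the ring is expected to behave in the same way, with no step beyond the scatter clearly indicated; if anything, a slightly higher number is expected, since compound 1, also carrying its group in the 2-position, gave 8700 nM. Compound 4 is therefore estimated at 4500 nM, with a range from 2000 nM to 10000 nM, corresponding to an expected step of a 1.3-fold higher number from compound 3 to compound 4 (0.10 log units; within the scatter).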

Compound 4, half-maximal inhibitory concentration: 10500 nM
The estimate for compound 4 lay 2.3-fold (0.37 log units) below the measured number; measured number outside the range, above it.
By their numbers in this assay, from the lowest: compounds 3, 2, 1 and 4 (each within the scatter of the next, the first and the last beyond it).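

In this assay the exchange of 3-chlorophenyl for 2-chlorophenyl on the carbonyl carbon keeps the same atoms yet gives a 3.0-fold higher number from compound 3 to compound 4 (0.47 log units; beyond the scatter) and so shows that the place of the chlorine on the aryl ring can by itself carry the number beyond the scatter. Replacing 4-fluorophenyl with 2-chlorophenyl at this carbonyl carbon gives a 2.3-fold higher number from compound 2 to compound 4 (0.36 log units; beyond the scatter) and likewise separates the two compounds. Chloro in place of methoxy on an aromatic carbon gives a 1.2-fold higher number from compound 1 to compound 4 (0.08 log units; within the scatter) and so the 2-methoxyphenyl and 2-chlorophenyl compounds cannot be ranked against each other, though compound 2 cannot be ranked against compound 1 either.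

Going by these compounds, how an aryl ring carrying an amine or a carboxylic acid, or a longer chain in place of the aryl group, would read here remains open. No supporting measurement bears on why the place of the chlorine moves the number.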